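This account rests on a few compounds, and the source may have more. Where it says the series, first, only, none or still open, it means among the compounds named here.

Compounds measured so far:
- compound 1, `O=C(O)CCC/C=C\C[C@H]1C(=O)C[C@@H](O)[C@@H]1/C=C/[C@@H](O)COc1ccccc1`: in an ADME assay on CHO cells for agonist activity at prostacyclin receptor (Homo sapiens), read by HTRF and cAMP accumulation (on this read-out lower numbers stand for an effect already at smaller amounts and higher numbers for an effect only at larger amounts of compound), compound 1 has "not determined" (no result reported)
- compound 2, `O=C(O)CCCCC1=CC[C@@H]2[C@@H](/C=C/[C@@H](O)COc3ccccc3)[C@H](O)C[C@@H]2OC1`: compound 2 gives > 10000 nM, which is a limit of this assay
- compound 3, `O=C(O)CC[C@@H]1CCC[C@@H]2[C@@H](/C=C/[C@@H](O)COc3ccccc3)[C@H](O)C[C@@H]2O1`: compound 3 gives 2000 nM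

Among the compounds with values here, compound 3 thus carries the only number in this assay; compound 2 sits at the limit of > 10000 nM in this assay, at which 1 of the 3 values shown sits, and compound 1 has no result. Compound 4, `O=C(O)CC[C@H]1CCC[C@@H]2[C@@H](/C=C/[C@@H](O)COc3ccccc3)[C@H](O)C[C@@H]2O1`, is not yet measured. The change from compound 3 to compound 4 is the two compounds have the same atoms and bonds and differ only in configuration as drawn: 1 of 7 stereo elements differ; a stereocentre at a saturated ring carbon is drawn S in compound 3 and R in compound 4. Within the data shown here, no measured pair tells how such an inversion moves this assay. With one data point as the anchor and no direction known, compound 4 is expected to lie in the range 500 nM to 20000 nM, around 3000 nM, a step of a 1.5-fold higher number from compound 3 to compound 4 (0.18 log units; within the scatter) that is expected to be small against the scatter.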

Compound 4, half-maximal effective concentration: > 10000 nM
Compound 4: no number, only a limit; the forecaster's own chance of this, stated with the estimate: 30%; middle value at least 3.3-fold (0.52 log units) away from the limit.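

In this assay, inverting this saturated ring carbon from S to R gives an at least 5.0-fold higher number from compound 3 to compound 4 (0.69 log units; beyond the scatter), the first measured sign that the configuration at this stereocentre matters. The step can be placed on this one stereocentre because nothing else changes: the fact that compounds 3 and 4 differ only in the configuration as drawn. Compound 4 has a limit rather than a number: the limit of > 10000 nM in this assay, at which 2 of the 4 values shown sit.

On these data alone, how large the step truly is remains open, as does the effect of inverting any of the other stereocentres. Also open, as far as these compounds go, is whether the S configuration would keep its advantage with a longer chain carrying the carboxylic acid, or with an amide in place of that acid.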